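Esterifying the diacid of compound 1: expected solubility

This account rests on a few compounds, and the source may have more. Where it says the series, first, only, none or still open, it means among the compounds named here.

Compound 1 `Nc1nc(N)c2nc(CN(Cc3ccc(B(O)O)cc3)c3ccc(C(=O)N[C@@H](CCC(=O)O)C(=O)O)cc3)cnc2n1`: 83000 nM
Compound 2 `COC(=O)CC[C@H](NC(=O)c1ccc(N(C)Cc2cnc3nc(N)nc(NC(=O)OCc4ccc(B(O)O)cc4)c3n2)cc1)C(=O)OC`: 3000 nM
Compound 3 `COC(=O)CC[C@H](NC(=O)c1ccc(N(C)Cc2cnc3nc(N)nc(NC(=O)OCc4ccc(B(O)O)c(C)c4)c3n2)cc1)C(=O)OC`: 3100 nM

In a physicochemical assay for solubility, read by HPLC, in phosphate buffer, measured as kinetic solubility, with a stated time of 20 h (a lower number here means a less soluble compound, a higher number a more soluble compound), compound 1 gives the highest of the three numbers; compound 3 lies a good way below it, and compound 2 lies furthest below. Compound 4 `COC(=O)CC[C@H](NC(=O)c1ccc(N(Cc2ccc(B(O)O)cc2)Cc2cnc3nc(N)nc(N)c3n2)cc1)C(=O)OC` differs from compound 1 by 1,3-bis(methoxycarbonyl)propyl in place of 1,3-dicarboxypropyl on an amide-type nitrogen. Among the compounds with values here, no measured pair shows this change on its own; the only measured step, a 1.0-fold higher number from compound 2 to compound 3 (0.01 log units; within the scatter), concerns a different site. Compounds 2 and 3, which both carry the 1,3-bis(methoxycarbonyl)propyl group, sit far below compound 1, so the expectation is a marked fall in this assay, estimated as a 17-fold lower number from compound 1 to compound 4 (1.22 log units; beyond the scatter). For compound 4 the estimate is 5000 nM, with a range from 1500 nM to 20000 nM.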

Compound 4, solubility: 4100 nM
Beside the measured number, compound 4's estimate is 1.2-fold (0.09 log units) above it; measured number inside the range.
By their numbers in this assay, from the lowest: compounds 2, 3 and 4 (each within the scatter of the next); then compound 1.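

Taken alone in this assay, 1,3-bis(methoxycarbonyl)propyl in place of 1,3-dicarboxypropyl on the amide-type nitrogen gives a 20-fold lower number from compound 1 to compound 4 (1.31 log units; beyond the scatter), a large step. The earlier compounds shown here gave no single-change reading at this position, since compound 2 and compound 3 differ from compound 1 in more than one place. Nothing shown here accounts for the size of this step. Still open, going by these compounds, is whether a monomethyl ester, keeping one carboxylic acid, would give a step of similar size. Ethyl esters or primary amides at this position also remain open.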